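The source may hold more compounds than are shown below. What is called first, only, known or untested is meant among the compounds shown, and "the series" means these compounds.

Measured compounds:
- Compound 1, `COc1ccccc1S(=O)(=O)/C=C/c1ccncc1`: 96.8%
- Compound 2, `COc1ccc(S(=O)(=O)/C=C/c2ccncc2)cc1`: 71%
- Compound 3, `COc1ccccc1S(=O)(=O)/C=C/c1cncnc1`: 100%

All three compounds were examined in an ADME assay on BV-2 cells (Mus musculus) for cytotoxicity, with a stated time of 24 h, tested at 10 uM; on this read-out higher numbers stand for a weaker effect at the one concentration tested and lower numbers for a stronger effect. In this assay compound 1 gives 96.8%, and compound 3 gives 100%. The two share one core and differ only by the change (pyrimidin-5-yl in place of pyridin-4-yl on a double-bonded chain carbon bound to a double-bonded chain carbon), and the step it made, a number 3.2 percentage points higher from compound 1 to compound 3 (within the scatter), lies within the scatter of this kind of measurement, so the two values cannot be ordered against each other. Compound 2 is built from the same atoms as compound 1, joined differently; the difference between the two cores is not broken down here. In this assay compound 2 gives 71%, the lowest of the three numbers, and its distance to both compound 1 and compound 3 is beyond the scatter.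

Compound 4, `COc1ccc(S(=O)(=O)/C=C/c2cncnc2)cc1`, has not yet been measured in this assay. It stands to compound 2 as compound 3 stands to compound 1, through the change (pyrimidin-5-yl in place of pyridin-4-yl on a double-bonded chain carbon bound to a double-bonded chain carbon), at the same place as before. For the measured compounds named here, since the one earlier instance of this change, a number 3.2 percentage points higher from compound 1 to compound 3 (within the scatter), was a step within the scatter, the step from compound 2 to compound 4 is expected to be small as well, at a number 3 percentage points higher from compound 2 to compound 4 (within the scatter), though a single precedent on a different core is a weak basis. For compound 4 in this assay the estimate is therefore 74%, with a likely range from 55% to 93%.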

Compound 4, a percentage reported as activity, at one concentration (the size of the read-out at that concentration, not a potency): 100%
Estimate against measurement, compound 4: 26 percentage points below; the whole stated range lies below it.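

In this assay, for the compounds shown here, putting pyrimidin-5-yl in place of pyridin-4-yl on the second core gave a clear step, a number 29 percentage points higher from compound 2 to compound 4 (beyond the scatter), whereas the same change on the first core gave no step that could be told from the scatter, so its size did not carry over from one core to the other: the same change on two cores in this assay, a number 3.2 percentage points higher (within the scatter) from compound 1 to compound 3 and a number 29 percentage points higher (beyond the scatter) from compound 2 to compound 4, 25.8 percentage points apart, beyond the scatter of two such steps For these four compounds, then, the effect of this change cannot be read from one core and applied to the other, and the pyridin-4-yl pair of compound 1 and compound 2 is the only pair of the two whose values lie apart beyond the scatter. This does not show what in the two cores sets the steps apart, and two instances of one change, each read at a single concentration, give no rule for any further core.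

The compounds shown leave open how the same change would behave on a core carrying an amine, a carboxylic acid or a longer chain in place of the methoxy group. They also leave open whether a ring such as pyridin-3-yl or a plain phenyl, standing at the place of the pyrimidin-5-yl, would follow compound 2 or compound 1 in this assay.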